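This account rests on a few compounds, and the source may have more. Where it says the series, first, only, none or still open, it means among the compounds named here.

Measured in a functional assay on L1210 cells (Mus musculus) for antiproliferative activity, read by MTT assay, with a stated time of 2 days; on this read-out higher numbers stand for weaker inhibition and lower numbers for stronger inhibition:
- Compound 1 `O=C1c2ccccc2C(=O)N1C/C=C\Cn1cc(C#Cc2ccc(Br)cc2)c(=O)[nH]c1=O`: 448000 nM
- Compound 2 `CCCCCC#Cc1cn(C/C=C/CN2C(=O)c3ccccc3C2=O)c(=O)[nH]c1=O`: > 500000 nM (a limit of the assay, not a number)

For the measured compounds named here, compound 1 holds the only true number in this small set, and that number is high, which on this read-out means weak inhibition. The other entry, for compound 2, is only a limit.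

Compound 3 `O=C1c2ccccc2C(=O)N1C/C=C\Cn1cc(C#CCCc2ccccc2)c(=O)[nH]c1=O` keeps the core of compound 1 and changes one group: phenethyl in place of 4-bromophenyl on a triple-bonded carbon. In words, phenethyl takes the place of 4-bromophenyl on a triple-bonded carbon. Going by the values given here, no step between measured compounds shows what such a swap does, so the expectation rests on compound 1 at 448000 nM alone. The expected step of a 1.5-fold lower number from compound 1 to compound 3 (0.17 log units; within the scatter) is small, within the usual scatter of this assay, with no firm direction. For compound 3 the estimated value is 300000 nM, with an expected range of 80000 nM to 600000 nM.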

Compound 3, half-maximal inhibitory concentration: 143000 nM
Estimate against measurement, compound 3: 2.1-fold (0.32 log units) above, and the stated range covers the measured number.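

In this assay, for the compounds shown here, phenethyl in place of 4-bromophenyl on a triple-bonded carbon gives a 3.1-fold lower number from compound 1 to compound 3 (0.50 log units; beyond the scatter), the first sign in these compounds that the group held at this place can shift the read-out. Both groups hold one six-membered aromatic ring of carbon only, yet this single step does not separate the loss of the bromine from the change in the link to the ring. Even so, compound 3 at 143000 nM keeps a high number, which here still means weak inhibition.

Compound 2 gives only a limit, not a number: the limit of > 500000 nM in this assay, at which 1 of the 3 values shown sits. On these data alone, whether an amine or a carboxylic acid on this triple-bonded carbon would bring the number lower, or whether the ring itself is needed there, stays open.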